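Dropping One Fluoro from a Difluorophenyl Ring

The source may report more compounds than this note shows. Statements on the series, on what has been measured and on what is new or still open speak of the compounds shown alone.

Measured compounds:
Compound 1, `COc1ccc(C2=C(c3ccc(SC)cc3)CC3CCCN3C2=O)cc1OC(=O)C1CCCN1C(=O)OC(C)(C)C`: in a functional assay on NCI-H520 cells (Homo sapiens) for cytotoxicity (on this read-out higher numbers stand for weaker inhibition of growth and lower numbers for stronger inhibition of growth), compound 1 gives 5000 nM.
Compound 2, `CSc1ccc(C2=C(c3ccc(F)c(F)c3)C(=O)N3CCCC3C2)cc1`: compound 2 gives 200 nM.
Compound 3, `CSc1ccc(C2=C(c3ccc(F)c(C)c3)C(=O)N3CCCC3C2)cc1`: compound 3 gives 500 nM.

Compound 2 has the lowest number of the three and so inhibits growth most strongly; compound 3 lies nearest to it and compound 1 far off. Compound 4, `CSc1ccc(C2=C(c3ccc(F)cc3)C(=O)N3CCCC3C2)cc1`, differs from compound 2 by hydrogen in place of fluoro on an aromatic carbon. Going by the values given here, the only measured step that bears on this change touches the same fluoro, and it gave a 2.5-fold higher number from compound 2 to compound 3 (0.40 log units; beyond the scatter). Taking that fluoro away rather than swapping it for methyl is expected to weaken growth inhibition somewhat less, by about a 1.8-fold higher number from compound 2 to compound 4 (0.24 log units; within the scatter) in this assay. Compound 4 is therefore estimated at 350 nM, with a range from 150 nM to 900 nM.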

Compound 4, concentration for 50% growth inhibition: 250 nM
Compound 4: the middle estimate sits 1.4-fold (0.15 log units) above what was measured, and the stated range covers the measured number.
By their numbers in this assay, from the lowest: compounds 2, 4 and 3 (each within the scatter of the next, the first and the last beyond it); then compound 1.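

In this assay, going from 3,4-difluorophenyl to 4-fluorophenyl gives a 1.3-fold higher number from compound 2 to compound 4 (0.10 log units; within the scatter) and so costs no measurable growth inhibition: this fluoro can go. Hydrogen in place of methyl gives a 2.0-fold lower number from compound 3 to compound 4 (0.30 log units; within the scatter) at the same place, so hydrogen cannot be told apart from either fluoro or methyl, and only fluoro and methyl differ beyond the scatter. Nothing here explains this result.
Still open, from the compounds shown here alone, is how an amine or a nitrile would behave at this place, and whether the remaining fluoro, kept in compound 2, compound 3 and compound 4, matters at all.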